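The source may report more compounds than this note shows. Statements on the series, on what has been measured and on what is new or still open speak of the compounds shown alone.

Three hydroxamic acids had been measured in an assay on Sf9 cells for inhibition of protein deacetylase HDAC6 (Homo sapiens), read by fluorescence (a lower number here means a stronger inhibitor, a higher number a weaker inhibitor), when compound 4 came up. Compound 1 `Cc1ccc(C(=O)NO)cc1F` gives 49 nM in this assay, compound 2 `Nc1ccc(C(=O)NO)cc1` gives 389 nM, and compound 3 `CC(=O)Nc1ccc(C(=O)NO)cc1F` gives 58 nM. Compound 3 thus stands second highest of the three numbers: its nearest neighbour is compound 1, whose number lies within the scatter of it, and its furthest is compound 2, whose number lies beyond the scatter above it. Among the compounds with values here, the one step among the measured compounds that changes a single place, a 1.2-fold higher number from compound 1 to compound 3 (0.07 log units; within the scatter), swaps acetamido for methyl on an aromatic carbon and stays within the scatter.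

Compound 4 `Nc1ccc(C(=O)NO)cc1F` differs from compound 3 by hydrogen in place of acetyl on a nitrogen on an aromatic ring. Within the data shown here, no measured step covers the same change, so it bears on compound 4 only indirectly. What the numbers do show is that compound 2, which carries the amino group without the fluorine, gives 389 nM, a number well above that of compound 3. On that basis compound 4 is expected to lose some potency, giving a step of a 2.8-fold higher number from compound 3 to compound 4 (0.44 log units; beyond the scatter). Compound 4 is therefore estimated at 160 nM in this assay, with a range from 55 nM to 450 nM.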

Compound 4, half-maximal inhibitory concentration: 183 nM
The estimate for compound 4 lay 1.1-fold (0.06 log units) below the measured number, and the stated range covers the measured number.
By their numbers in this assay, from the lowest: compounds 1 and 3 (each within the scatter of the next); then compound 4; then compound 2.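

Hydrogen in place of acetyl on a nitrogen on an aromatic ring is a real change in this assay, with a 3.2-fold higher number from compound 3 to compound 4 (0.50 log units; beyond the scatter), and amino in place of methyl on an aromatic carbon gives a step of similar size, with a 3.7-fold higher number from compound 1 to compound 4 (0.57 log units; beyond the scatter); so amino at this place stands apart from both methyl and acetamido, which the earlier step, a 1.2-fold higher number from compound 1 to compound 3 (0.07 log units; within the scatter), could not tell apart. The series also gains its first reading of fluoro in place of hydrogen on an aromatic carbon, with a 2.1-fold lower number from compound 2 to compound 4 (0.33 log units; beyond the scatter), a modest step beyond the scatter that, with the amino group in place, goes towards a lower number, though this single pair sets no pattern. Nothing given here accounts for any of these steps.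

The compounds shown leave open whether fluoro in place of hydrogen moves the number in the same direction when methyl or acetamido stands in place of amino. They also leave open how a longer acyl chain such as propionyl, or a methyl group, on that nitrogen would compare with acetyl and hydrogen.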